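A few compounds are considered here, and "the series" means these few. Any claim that something is new, unique, unknown or untested is made for them only; others in the source may bear on it.

Measured in an ADME assay on MT4 cells (Homo sapiens) for cytotoxicity, read by MTT assay; on this read-out higher numbers stand for lower toxicity in this test and lower numbers for higher toxicity in this test:

- compound 1, `O=C1c2ccccc2C(=O)N1CCOC(=S)N(C(=O)c1c(F)cccc1F)c1ccc(Cl)cc1`: 39000 nM
- compound 2, `O=C1c2ccccc2C(=O)N1CCOC(=S)N(C(=O)c1cccc(Cl)c1Cl)c1ccc(Cl)cc1`: 54000 nM
- compound 3, `O=C1c2ccccc2C(=O)N1CCOC(=S)N(C(=O)c1c(Cl)cccc1Cl)c1ccc(Cl)cc1`: 20000 nM

Compound 3 sits at the low end of the three numbers in this assay. Its gap to compound 1 is small, a 2.0-fold lower number from compound 1 to compound 3 (0.29 log units; within the scatter), whereas the step of a 2.7-fold lower number from compound 2 to compound 3 (0.43 log units; beyond the scatter) is beyond the scatter. The remaining measured step, a 1.4-fold higher number from compound 1 to compound 2 (0.14 log units; within the scatter), is within the scatter. Across the three compounds, then, swapping the aryl group on the carbonyl carbon moves the number by only a modest amount.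

Compound 4, `O=C1c2ccccc2C(=O)N1CCOC(=S)N(C(=O)c1ccc2ccccc2c1)c1ccc(Cl)cc1`, differs from compound 3 at the same place: naphthalen-2-yl in place of 2,6-dichlorophenyl on a carbonyl carbon. Going by the values given here, no measured step involves naphthalen-2-yl, so the expectation rests only on the narrow spread seen so far among the three carbonyl-attached aryl groups. A step of a 1.5-fold higher number from compound 3 to compound 4 (0.18 log units; within the scatter) is expected, within or just beyond the scatter, most likely toward a somewhat higher number since compound 3 gives the low end of the set. For compound 4 in this assay the estimate is 30000 nM, with a range from 12000 nM to 80000 nM.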

Compound 4, half-maximal cytotoxic concentration: 37000 nM
Compound 4: the middle estimate sits 1.2-fold (0.09 log units) below what was measured; low and high end bracket the measured number.
By their numbers in this assay, from the lowest: compounds 3, 4, 1 and 2 (each within the scatter of the next, the first and the last beyond it).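

In this assay, naphthalen-2-yl on a carbonyl carbon, with 2 six-membered aromatic rings of carbon only and no halogen, stays within the scatter of each of the three halogenated phenyl groups: a 1.9-fold higher number from compound 3 to compound 4 (0.27 log units; within the scatter), a 1.5-fold lower number from compound 2 to compound 4 (0.16 log units; within the scatter) and a 1.1-fold lower number from compound 1 to compound 4 (0.02 log units; within the scatter). Going by these compounds alone, the earlier compounds covered only single halogenated phenyl rings, so the narrow spread at this position now extends to a larger, halogen-free aryl group, and the one step beyond the scatter remains a 2.7-fold lower number from compound 2 to compound 3 (0.43 log units; beyond the scatter). No available data bear on the origin of this narrow spread.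

As far as these compounds go, whether the number stays in this range with a non-aromatic group at this position, such as cyclohexyl, or with an aminomethyl or carboxylic acid substituent on the aryl ring, remains open. From the compounds shown here alone, how changes elsewhere on the shared core would compare with this flat response is also open.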